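The source may report more compounds than this note shows. Statements on the series, on what has been measured and on what is new or still open speak of the compounds shown alone.

Measured compounds in the series:

- compound 1, `C=CCOc1c(C)c(C)c2c(c1C)CCC(C)(COc1cccc(/C=C3\SC(=O)NC3=O)c1)O2`: 92%
- compound 2, `CC(C)=CCOc1c(C)c(C)c2c(c1C)CCC(C)(COc1ccc(/C=C3\SC(=O)NC3=O)cc1F)O2`: 87%

In a functional assay on MCF7 cells (Homo sapiens), tested at 5 uM (on this read-out higher numbers stand for a weaker effect at the one concentration tested and lower numbers for a stronger effect), compound 1 gives 92% and compound 2 gives 87%. Compound 2 has the lower of the two numbers, but its gap to compound 1 is within the scatter, so no order between the two compounds can be read from these values. Both numbers lie high on this read-out, which corresponds to a weak effect at the single concentration tested. Going by the values given here, the two measured compounds differ from each other in more than one place, so no single-change step between measured compounds is available, and nothing is known from the data about how any one change moves this read-out.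

Compound 3, `CC(C)=CCOc1c(C)c(C)c2c(c1C)CCC(C)(COc1ccc(/C=C3\SC(=O)NC3=O)cc1C)O2`, has not been measured. It differs from compound 2 in one place: methyl in place of fluoro on an aromatic carbon. Among the compounds with values here, with no measured single-change step to lean on, the expected step of no change at the digits printed from compound 2 to compound 3 (within the scatter) is small, none beyond the scatter, in either direction. Compound 3 is therefore estimated at 87% in this assay, with a range from 72% to 100%.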

Compound 3, a percentage reported as activity, at one concentration (the size of the read-out at that concentration, not a potency): 56%
Compound 3: middle estimate off by 31 percentage points, on the high side, and the stated range ends above it.
By their numbers in this assay, from the lowest: compound 3; then compounds 2 and 1 (each within the scatter of the next).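

In this assay, methyl in place of fluoro on an aromatic carbon ortho to a large group gives a number 31 percentage points lower from compound 2 to compound 3 (beyond the scatter), the first single-change step available in this series. The position is therefore sensitive to this exchange: one heavy atom replaces one heavy atom, no hydrogen-bond donor, hydrogen-bond acceptor or net charge enters or leaves, and the read-out still moves towards a stronger effect at the one concentration tested. No measurement in hand bears on what lies behind this step.

The compounds shown do not tell whether the step is particular to methyl, or how chloro, methoxy, an amine or a longer chain such as ethyl would read on the same aromatic carbon. Also open, going by these compounds, is whether a methyl there would give a step of similar size with the other structural features of compound 1 in place, and, with only one concentration tested, whether the stronger effect at that concentration would hold at other concentrations.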